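The compounds below may be only part of what the source reports. "The series", "measured", "known", "first", "only" and "open" are said of these compounds alone.

Working notes on the series. All four compounds share one core. Compound 1, `CC(C)n1cc(-c2ccnc3[nH]c(C4CCNCC4)cc23)ccc1=O`, carries isopropyl on the aromatic nitrogen and an unsubstituted secondary amine. In an ADME assay on microsomes from liver (Homo sapiens) for metabolic stability (on this read-out higher numbers stand for fast clearance and lower numbers for slow clearance), compound 1 gives < 3 uL/min, which is a limit of the assay rather than a number (the limit of < 3 uL/min in this assay, at which 1 of the 3 values shown sits). Compound 2, `COc1cc(F)ccc1-c1ccnc2[nH]c(C3CCN(CC(=O)N(C)C)CC3)cc12`, carries the dimethylamide side chain on the amine; in this assay compound 2 gives 14 uL/min. Compound 3, `CN(C)C(=O)CN1CCC(c2cc3c(-c4ccc(=O)n(CCC5CCOCC5)c4)ccnc3[nH]2)CC1`, keeps that side chain and carries 2-(oxan-4-yl)ethyl on the aromatic nitrogen; in this assay compound 3 gives 19 uL/min. Of the two numbers measured, those of compound 3 and compound 2 sit within the scatter of each other, so no order can be read between them; the third value is only a limit.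

Compound 4, `CC(C)n1cc(-c2ccnc3[nH]c(C4CCN(CC(=O)N(C)C)CC4)cc23)ccc1=O`, differs from compound 3 in one place: isopropyl in place of 2-(oxan-4-yl)ethyl on an aromatic nitrogen. Compound 4 thus carries the same isopropyl as compound 1 together with the side chain of compound 2 and compound 3. Going by the values given here, no measured step covers this change directly. Compound 4 is expected to move toward slower clearance than compound 3, an estimated step of a 2.7-fold lower number from compound 3 to compound 4 (0.43 log units; beyond the scatter), beyond the scatter. For compound 4 the estimate in this assay is 7 uL/min, with a range from 3 uL/min to 16 uL/min, and a fair chance that only a limit is reported.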

Compound 4, intrinsic clearance in a liver preparation (reported as CLH), per the amount of preparation that the assay uses: < 3 uL/min
Compound 4: no number, only a limit; the forecaster's own chance of this, stated with the estimate: 25%; middle value at least 2.3-fold (0.36 log units) from the limit.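

Going by these compounds alone, on the aromatic nitrogen, with the dimethylamide side chain held in place, isopropyl in place of 2-(oxan-4-yl)ethyl gives the first readable step at this position: an at least 6.3-fold lower number from compound 3 to compound 4 (0.80 log units; beyond the scatter). The group of 10 heavy atoms with its six-membered aromatic ring with 1 hetero atom, in place of the group of 9 heavy atoms with its six-membered aromatic ring of carbon only, also separates two compounds that carry the same side chain, giving an at least 4.6-fold lower number from compound 2 to compound 4 (0.66 log units; beyond the scatter). In this assay compound 4 gives a limit and not a number, so the true size of both steps stays unknown: the limit of < 3 uL/min in this assay, at which 2 of the 4 values shown sit.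

Going by these compounds, compound 1 and compound 4 both stand at a limit, so the step between them cannot be read, and what (dimethylcarbamoyl)methyl in place of hydrogen on the amine nitrogen does in the isopropyl compounds remains open. Also open, on these data alone, is how the read-out moves on the aromatic nitrogen between isopropyl and 2-(oxan-4-yl)ethyl, for instance with a plain propyl chain, a cyclohexylmethyl group, or a longer chain ending in a carboxylic acid.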